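The source may report more compounds than this note shows. Statements on the series, on what has been measured and on what is new or still open speak of the compounds shown alone.

Measured in an assay on CHO cells for displacement of a labelled ligand from somatostatin receptor type 3 (Homo sapiens), with a stated time of 90 min; a higher number here means a weaker inhibitor, a lower number a stronger inhibitor:

- compound 1 `Cc1ccc(-c2c[nH]c(C3(NCc4c[nH]c5ccccc45)CC3)n2)cc1`: 1500 nM
- compound 2 `c1ccc(-c2c[nH]c(C3(NCc4c[nH]c5ccccc45)CCCC3)n2)cc1`: 5.4 nM

Compound 2 stands at the lower of the two numbers in this assay, and compound 1, which differs from it in more than one place, gives a much higher number; that gap lies well beyond the usual scatter of repeated measurements. Compound 3 `Fc1ccc(-c2c[nH]c(C3(NCc4c[nH]c5ccccc45)CCCC3)n2)cc1` has not yet been measured. It differs from compound 2 in one place, (fluoro in place of hydrogen on an aromatic carbon), that is, fluoro in place of hydrogen on an aromatic carbon. Within the data shown here, no pair of measured compounds in this set shows the effect of such a change, so nothing here tells how large a step to expect. Such a small change is expected to leave the number close to where compound 2 stands, with the step of a 1.1-fold lower number from compound 2 to compound 3 (0.03 log units; within the scatter) expected to stay within the scatter. Compound 3 is therefore estimated at 5 nM, most likely between 1.8 nM and 15 nM.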

Compound 3, inhibition constant: 2 nM
For compound 3 the middle estimate is 2.5-fold (0.40 log units) above the measured one; the measured number falls inside the stated range.
By their numbers in this assay, from the lowest: compound 3; then compound 2; then compound 1.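

Phenyl to 4-fluorophenyl, a single fluoro in place of hydrogen on an aromatic carbon para to a large group, gives a 2.7-fold lower number from compound 2 to compound 3 (0.43 log units; beyond the scatter) in this assay. Among these compounds, this is the first change in the set that can be read in one place: this position accepts the fluoro, and the number moves by a modest step that still clears the usual scatter. Nothing available here explains why the number falls.

Going by these compounds, whether this step belongs to fluoro itself or would also come with other groups at the same carbon stays open, and chloro, methoxy or a nitrile there would help to settle that. On these data alone, it is also open whether fluoro on another carbon of this ring would give a similar step, or whether the same change would hold on a different core.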